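This account rests on a few compounds, and the source may have more. Where it says the series, first, only, none or still open, it means among the compounds named here.

Compound 1 `COc1ccc2c(=O)c(/C=C/C(=O)Nc3cccc(Cl)c3)coc2c1` gives 470 nM in a functional assay on A549 cells (Homo sapiens) for inhibition, read by MTT assay, with a stated time of 48 h; a lower number here means a stronger inhibitor, a higher number a weaker inhibitor.
Compound 3 `COc1ccc2c(=O)c(/C=C/C(=O)NCc3ccccc3)coc2c1` gives 11800 nM in this assay.
Compound 2 `O=C(/C=C/c1coc2cc(O)ccc2c1=O)NCc1ccccc1` is reported in this assay only as a limit, > 100000 nM.

Compound 2 therefore sits at the limit of > 100000 nM in this assay, at which 1 of the 3 values shown sits, and its true number is not known beyond that bound. Compound 4 `O=C(/C=C/c1coc2cc(O)ccc2c1=O)Nc1ccccc1` differs from compound 2 by phenyl in place of benzyl on an amide-type nitrogen. The measured step that bears on this runs the other way: a 25-fold higher number from compound 1 to compound 3 (1.40 log units; beyond the scatter). The step of an at least 8.4-fold lower number from compound 2 to compound 3 (0.92 log units; beyond the scatter) adds only a lower bound on how far compound 2 lies from compound 3. Reversing the benzyl-to-aryl direction, a large gain is expected for compound 4, though the absent chlorine and the unknown starting point of compound 2 widen the range. Compound 4 is estimated at 20000 nM, between 4000 nM and 150000 nM. That corresponds to an expected step of an at least 5.0-fold lower number from compound 2 to compound 4 (0.69 log units; beyond the scatter).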

Compound 4, half-maximal inhibitory concentration: 24400 nM
Compound 4: the middle estimate sits 1.2-fold (0.09 log units) below what was measured, within the range that was stated.
By their numbers in this assay, from the lowest: compound 1; then compound 3; then compound 4. At a limit, above all of these: compound 2.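

On the core of compound 2, phenyl in place of benzyl on the amide-type nitrogen gives an at least 4.0-fold lower number from compound 2 to compound 4 (0.61 log units; beyond the scatter). Benzyl therefore carries the higher number on this core too, in the same direction as a 25-fold higher number from compound 1 to compound 3 (1.40 log units; beyond the scatter), and this holds with a phenyl that has no chlorine. As far as these compounds go, the true size of the new step stays unknown because compound 2 is reported only as a limit: the limit of > 100000 nM in this assay, at which 1 of the 4 values shown sits.

From the compounds shown here alone, what remains open is how an amine or a carboxylic acid on that phenyl would read in this assay, and how a longer chain in place of benzyl would.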